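Extending the Ester from Methyl to Cyclohexylmethyl

The compounds below may be only part of what the source reports. "The series", "measured", "known", "first", "only" and "open" are said of these compounds alone.

Compound 2 `CCCCc1nc(C)c(CC(=O)OC)c(=O)n1Cc1ccc(-c2ccccc2-c2noc(=O)[nH]2)cc1`: 47.1%
Compound 1 `CCCCc1nc(C(C)C)c(CC(=O)OC)c(=O)n1Cc1ccc(-c2ccccc2-c2noc(=O)[nH]2)cc1`: 9.4%

In an ADME assay on microsomes from liver (Mus musculus) for metabolic stability, with a stated time of 30 min (a higher number here means that more of the compound is left, a lower number that less of the compound is left), compound 2 gives 47.1%, the higher of the two numbers; compound 1 gives 9.4%. Going by the values given here, the only measured step, a number 37.7 percentage points higher from compound 1 to compound 2 (beyond the scatter), changes a group on an aromatic carbon. Compound 3 `CCCCc1nc(C)c(CC(=O)OCC2CCCCC2)c(=O)n1Cc1ccc(-c2ccccc2-c2noc(=O)[nH]2)cc1` differs from compound 2 elsewhere: cyclohexyl in place of hydrogen on a saturated chain carbon bound to an oxygen next to a carbonyl group. Among the compounds with values here, no measured step touches this place, so the change is an open question, and only a modest step, in either direction, is expected: a number 7.1 percentage points lower from compound 2 to compound 3 (within the scatter). Compound 3 is therefore estimated at 40%, within 12% to 70%.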

Compound 3, percent of the compound remaining: 8.9%
Compound 3: the middle estimate sits 31.1 percentage points above what was measured; measured number outside the range, below it.
By their numbers in this assay, from the lowest: compounds 3 and 1 (each within the scatter of the next); then compound 2.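

In this assay, cyclohexylmethyl in place of methyl on the ester gives a number 38.2 percentage points lower from compound 2 to compound 3 (beyond the scatter), a large step. So the ester end of the molecule, which the earlier pair left untouched, can also shift this number beyond the scatter, not only the group on the aromatic carbon. Nothing measured here says why the number falls.

Still open, going by these compounds, is what an ethyl ester, a benzyl ester or the free carboxylic acid would give here, and whether the lower number goes with the cyclohexyl ring itself.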